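Benzamide Trimming in a Pyrazole Series Against Ovarian Cancer Cells

The compounds below may be only part of what the source reports. "The series", "measured", "known", "first", "only" and "open" are said of these compounds alone.

Measured so far:
Compound 1, `COc1cc(-c2nn(-c3cccc(NC(=O)Nc4cccc(C(F)(F)F)c4)c3)cc2-c2ccncc2)ccc1Cl`: 2020 nM
Compound 2, `COc1cc(-c2nn(-c3cccc(NC(=O)c4ccc(Cl)c(C(F)(F)F)c4)c3)cc2-c2ccncc2)ccc1Cl`: 9290 nM

Both were tested in a functional assay on SK-OV-3 cells (Homo sapiens) for inhibition, read by sulforhodamine B assay, with a stated time of 48 h; a higher number here means a weaker inhibitor of growth, a lower number a stronger inhibitor of growth. Among the compounds with values here, compound 2 stands as the higher of the two numbers, with compound 1 its only neighbour at a 4.6-fold higher number from compound 1 to compound 2 (0.66 log units; beyond the scatter), a change that swapped an amino-linked ring for a directly attached ring on the carbonyl carbon.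

Compound 3, `COc1cc(-c2nn(-c3cccc(NC(=O)c4ccccc4)c3)cc2-c2ccncc2)ccc1Cl`, keeps the amide of compound 2 but strips its ring bare: phenyl in place of 4-chloro-3-(trifluoromethyl)phenyl on a carbonyl carbon. Within the data shown here, no measured step touches exactly this change. Among the measured compounds shown here, the one step available, from compound 1 to compound 2, moved the number in the weaker direction when the ring on the carbonyl carbon became the chlorinated, trifluoromethyl-bearing one, but it changed the linker at the same time, so it does not tell how the substituents alone matter.

Because compound 2 already sits at 9290 nM, the expectation for compound 3 is a number of a similar order, with wide uncertainty. The expected step from compound 2 to compound 3 is a 1.5-fold higher number from compound 2 to compound 3 (0.18 log units; within the scatter). Compound 3 is estimated at 14000 nM, within 4000 nM to 50000 nM.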

Compound 3, concentration for 50% growth inhibition: 1070 nM
Estimate against measurement, compound 3: 13-fold (1.12 log units) above; the measured number lies below the stated range.
By their numbers in this assay, from the lowest: compounds 3 and 1 (each within the scatter of the next); then compound 2.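

In this assay, phenyl in place of 4-chloro-3-(trifluoromethyl)phenyl on the carbonyl carbon gives an 8.7-fold lower number from compound 2 to compound 3 (0.94 log units; beyond the scatter), which is beyond the scatter. The linker stays the same in this step, so it isolates what the earlier step could not: the amide-linked compound 3 is not held back in the way compound 2 is, and the weak number of compound 2 goes with its substituted ring rather than with the amide alone. The step of a 1.9-fold lower number from compound 1 to compound 3 (0.28 log units; within the scatter) lies within the scatter, so compound 1, with its (3-(trifluoromethyl)phenyl)amino group, and the much smaller bare phenyl of compound 3 cannot be told apart in this assay, and nothing available explains how the ring substituents act on growth inhibition.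

From the compounds shown here alone, the chlorine and the trifluoromethyl group left together in a single step, so the share of each in the change stays open. Going by these compounds, it also stays open how an amine or a carboxylic acid on the phenyl ring of compound 3 would move the number.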